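The compounds below may be only part of what the source reports. "The series", "measured", "known", "first", "only" and "open" are said of these compounds alone.

Measured in an ADME assay on NHDF cells (Homo sapiens) for cytotoxicity, read by MTT assay, with a stated time of 72 h; a lower number here means a stronger inhibitor, a higher number a weaker inhibitor:
- Compound 1 `COc1ccccc1/C=C1\CCC/C(=C\c2ccc(OC)c(OC)c2)C1=O`: 18100 nM
- Compound 2 `COc1ccc(/C=C2\CCC/C(=C\c3ccc(O)cc3)C2=O)cc1OC`: 26100 nM

Only these two compounds have been measured so far, and compound 2 stands within the scatter of compound 1. Among the measured compounds shown here, the single measured step between them is a 1.4-fold higher number from compound 1 to compound 2 (0.16 log units; within the scatter). Compound 3 `COc1ccc(/C=C2\CCC/C(=C\c3cccc(Cl)c3Cl)C2=O)cc1OC` has not yet been measured in this assay. Compared with compound 2, it has this structural change: 2,3-dichlorophenyl in place of 4-hydroxyphenyl on a double-bonded chain carbon bound to a double-bonded ring carbon. The exchange lies on a double-bonded chain carbon bound to a double-bonded ring carbon, the same place that changes between compound 1 and compound 2. For the measured compounds named here, that step is therefore the only evidence that bears on it. Replacing 2-methoxyphenyl with 4-hydroxyphenyl there gave only a 1.4-fold higher number from compound 1 to compound 2 (0.16 log units; within the scatter). Going by the values given here, no measured compound carries 2,3-dichlorophenyl, so this evidence is thin and the range must stay wide. No step beyond the scatter is expected, and the estimated change is a 1.6-fold lower number from compound 2 to compound 3 (0.21 log units; within the scatter). For compound 3 the expected value is 16000 nM, with an estimated range of 6000 nM to 42000 nM.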

Compound 3, half-maximal inhibitory concentration: 18500 nM
Beside the measured number, compound 3's estimate is 1.2-fold (0.06 log units) below it; the measured number falls inside the stated range.
By their numbers in this assay, from the lowest: compounds 1, 3 and 2 (each within the scatter of the next).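

In this assay, putting 2,3-dichlorophenyl in place of 4-hydroxyphenyl on a double-bonded chain carbon bound to a double-bonded ring carbon gives a 1.4-fold lower number from compound 2 to compound 3 (0.15 log units; within the scatter), and putting it in place of 2-methoxyphenyl at the same place gives a 1.0-fold higher number from compound 1 to compound 3 (0.01 log units; within the scatter). Where a single exchange stood before, this place now holds three different groups whose numbers all lie within the scatter of one another, even though the entering group carries chlorine and has no hydrogen-bond donor or acceptor, while 4-hydroxyphenyl has both. No supporting measurement bears on why the numbers stay so close at this place.

The compounds shown leave open whether any group at this place can move the number beyond the scatter, for example a phenyl ring carrying an amine or a carboxylic acid, or a longer chain in place of the ring. They also leave open whether a change elsewhere on the shared core would do so, since all three compounds differ only at this one place.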